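Methoxy to isopropoxy: the same change on two cores

This account rests on a few compounds, and the source may have more. Where it says the series, first, only, none or still open, it means among the compounds named here.

Measured so far:
compound 1 `COc1cc(-c2ccc(O)c(O)c2)nc2ccccc12`: 40 nM
compound 2 `CC(C)Oc1cc(-c2ccc(O)c(O)c2)nc2ccccc12`: 20 nM
compound 3 `COc1cc(-c2ccc(O)cc2O)nc2ccccc12`: > 500 nM

In a functional assay on HT-22 cells (Mus musculus), read by MTT assay, with a stated time of 24 h (a lower number here means that less compound is needed, a higher number that more compound is needed for the effect), compound 1 gives 40 nM and compound 2 gives 20 nM. The change isopropyl in place of methyl on an oxygen on an aromatic ring gives a 2.0-fold lower number from compound 1 to compound 2 (0.30 log units; within the scatter). For compound 3 this assay reports only a limit, (the limit of > 500 nM in this assay, at which 1 of the 3 values shown sits). The difference between the core of compound 1 and the core of compound 3 is not broken down here.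

Compound 4 `CC(C)Oc1cc(-c2ccc(O)cc2O)nc2ccccc12` is not yet measured. It carries isopropyl in place of methyl on an oxygen on an aromatic ring, the same change as between compound 1 and compound 2, made at the same place on the other core. Because that earlier step was a 2.0-fold lower number from compound 1 to compound 2 (0.30 log units; within the scatter), only a small move is expected from compound 3 to compound 4, estimated as a step that the limit leaves unreadable from compound 3 to compound 4. Compound 4 is therefore expected at about 900 nM, between 300 nM and 3000 nM, most likely again reported as a limit.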

Compound 4, half-maximal effective concentration: 210 nM
Compound 4: the middle estimate sits 4.3-fold (0.63 log units) above what was measured; measured number below the stated range.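

In this assay, methoxy to isopropoxy on the core of compound 3 gives an at least 2.3-fold lower number from compound 3 to compound 4 (0.37 log units; beyond the scatter), a step beyond the scatter, whereas the step on the core of compound 1 stays within it. The value of compound 3, > 500 nM, is a limit. The change can thus be carried to the second core without loss in this assay, but the data do not show that it acts equally on both cores: the same change on two cores in this assay, a 2.0-fold lower number (0.30 log units; within the scatter) from compound 1 to compound 2 and an at least 2.3-fold lower number (0.37 log units; beyond the scatter) from compound 3 to compound 4; the limit leaves it open whether they differ

The compounds shown leave open whether a longer chain on that oxygen would continue the step seen with isopropyl. Also open, going by these compounds, is how an amine in place of the alkoxy group would read on either core.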